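The source may report more compounds than this note shows. Statements on the series, on what has been measured and on what is new or still open speak of the compounds shown alone.

Of the compounds shown here, three from this series have been measured in an assay on HEK-293T cells for inhibition of Bile acid receptor (Homo sapiens), read by a beta-lactamase reporter, with a stated time of 16 h; on this read-out lower numbers stand for stronger inhibition and higher numbers for weaker inhibition. Compound 1 `Cc1ccc(-c2nn(-c3ccc(F)cc3)cc2C(=O)Nc2ccc(C)c(S(=O)(=O)N3CCOCC3)c2)cc1` gives 2490 nM. Compound 2 `CCCCn1cc(C(=O)Nc2ccc(C)c(S(=O)(=O)N3CCOCC3)c2)c(-c2ccc(C)cc2)n1` gives 11500 nM, the second highest of the three numbers, close to compound 3 `Cc1ccc(NC(=O)c2cnn(-c3ccccc3)c2C(F)(F)F)cc1S(=O)(=O)N1CCOCC1`, which gives 11800 nM; those two values lie within the scatter of each other, while compound 1 sits well below both. For the measured compounds named here, the only single-point step among them is a 4.6-fold higher number from compound 1 to compound 2 (0.66 log units; beyond the scatter), which exchanged 4-fluorophenyl for butyl on the aromatic nitrogen of the shared core.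

Compound 4 `Cc1ccc(-c2nn(-c3ccccc3)cc2C(=O)Nc2ccc(C)c(S(=O)(=O)N3CCOCC3)c2)cc1` has not yet been measured. It differs from compound 2 by phenyl in place of butyl on an aromatic nitrogen. Going by the values given here, this is nearly the reverse of the measured step, with phenyl entering where 4-fluorophenyl had stood before butyl replaced it, so the one step that bears on the change is a 4.6-fold higher number from compound 1 to compound 2 (0.66 log units; beyond the scatter), and the reversal is expected to return most of that gain. Compound 4 is therefore expected to give a lower number than compound 2 in this assay, with a step of about a 4.1-fold lower number from compound 2 to compound 4 (0.61 log units; beyond the scatter). The estimate for compound 4 is 2800 nM, with a range from 1000 nM to 8000 nM.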

Compound 4, half-maximal inhibitory concentration: 2620 nM
The estimate for compound 4 lay 1.1-fold (0.03 log units) above the measured number; the range from low to high includes it.
By their numbers in this assay, from the lowest: compounds 1 and 4 (each within the scatter of the next); then compounds 2 and 3 (each within the scatter of the next).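

In this assay, the step from butyl to phenyl on the aromatic nitrogen is a 4.4-fold lower number from compound 2 to compound 4 (0.64 log units; beyond the scatter), so the difference seen earlier between compound 1 and compound 2 also appears with an unsubstituted phenyl group and does not depend on the fluoro group. The second comparison isolates that fluoro group directly: a 1.1-fold higher number from compound 1 to compound 4 (0.02 log units; within the scatter), which means that hydrogen and fluoro on this aromatic carbon cannot be told apart in this read-out, and both compounds with an aromatic ring at this position give lower numbers than compound 2 with its butyl chain. Nothing measured here explains why the phenyl and butyl groups differ.

Because phenyl differs from butyl both in holding a ring and in its count of heavy atoms, the compounds shown cannot separate these two features, and a cyclohexyl ring or a longer chain on the same nitrogen would be needed to tell them apart. They also leave open whether a group other than fluoro on the phenyl ring, such as methoxy, an amine or a carboxylic acid, would shift the number at all.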